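The source may report more compounds than this note shows. Statements on the series, on what has been measured and on what is new or still open speak of the compounds shown alone.

Compound 3 `COc1ccccc1-n1nc([C@@H]2CCO[C@@H](C(C)C)C2)cc1-c1ccc(Cl)cc1` gives 20 nM in an assay on HEK293 cells for inhibition of Voltage-dependent N-type calcium channel subunit alpha-1B (Homo sapiens), read by fluorescence and calcium flux, with a stated time of 5 min (a higher number here means a weaker inhibitor, a lower number a stronger inhibitor), the highest of the three numbers recorded for this series. Compound 1 `COc1ccccc1-n1nc(C2CC(C)(C)OC(C)(C)C2)cc1-c1ccc(Cl)cc1` gives 1 nM in this assay, and compound 2 `COc1ccccc1-n1nc(C2C[C@H](C)O[C@@H](C)C2)cc1-c1ccc(Cl)cc1` gives 2 nM. Here a 2.0-fold higher number from compound 1 to compound 2 (0.30 log units; within the scatter), whereas a 20-fold higher number from compound 1 to compound 3 (1.30 log units; beyond the scatter) and a 10-fold higher number from compound 2 to compound 3 (1.00 log units; beyond the scatter). Compound 4 `COc1ccccc1-n1nc([C@@H]2CCO[C@H](C(C)C)C2)cc1-c1ccc(Cl)cc1` differs from compound 3 in that (the two compounds have the same atoms and bonds and differ only in configuration as drawn: 1 of 2 stereo elements differ; a stereocentre at a saturated ring carbon is drawn R in compound 3 and S in compound 4). Among the measured compounds shown here, none of the measured steps bears directly on this change: each of them swaps one substitution pattern of the oxane for another rather than inverting a single centre. In the absence of such a comparison, the step is expected to stay within the scatter, so that no change at the digits printed from compound 3 to compound 4 (within the scatter) is the estimate. Compound 4 is therefore expected to give about 20 nM in this assay, within a range from 5 nM to 80 nM.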

Compound 4, half-maximal inhibitory concentration: 7 nM
Beside the measured number, compound 4's estimate is 2.9-fold (0.46 log units) above it, and the stated range covers the measured number.
By their numbers in this assay, from the lowest: compounds 1 and 2 (each within the scatter of the next); then compound 4; then compound 3.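

Inverting a single saturated ring carbon, from R to S, gives a 2.9-fold lower number from compound 3 to compound 4 (0.46 log units; beyond the scatter) in this assay, so configuration at this centre matters to the 2-isopropyloxan-4-yl compounds, which the earlier changes of substitution pattern could not show. The step can be put down to that centre alone, because of this: the fact that compounds 3 and 4 differ only in the configuration as drawn. Even so, the better of the two isopropyl compounds stays apart from the other oxanes, with a 3.5-fold higher number from compound 2 to compound 4 (0.54 log units; beyond the scatter) and a 7.0-fold higher number from compound 1 to compound 4 (0.85 log units; beyond the scatter).

The compounds shown leave open what inverting the other stereocentre would do, and whether an ethyl or tert-butyl group in place of isopropyl would show the same dependence on configuration.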